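Chloro in Place of Methyl Across Two Related Cores

This account rests on a few compounds, and the source may have more. Where it says the series, first, only, none or still open, it means among the compounds named here.

Compound 1 `Cc1ccc2c(c1)C1(C(=O)N2C)C(C#N)=C(N)Oc2cc3oc(-c4ccccc4)cc(=O)c3c(O)c21` and compound 2 `CN1C(=O)C2(C(C#N)=C(N)Oc3cc4oc(-c5ccccc5)cc(=O)c4c(O)c32)c2cc(Cl)ccc21` share one core and differ in a single substituent. In a functional assay on K562 cells (Homo sapiens) for antiproliferative activity, read by MTT assay, with a stated time of 48 h (on this read-out higher numbers stand for weaker inhibition and lower numbers for stronger inhibition), compound 1 gives 5870 nM, and compound 2 gives 4340 nM. The change between them is chloro in place of methyl on an aromatic carbon, and it made a step of a 1.4-fold lower number from compound 1 to compound 2 (0.13 log units; within the scatter).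

Compound 3 `Cc1cccc2c1N(Cc1ccccc1)C(=O)C21C(C#N)=C(N)Oc2cc3oc(-c4ccccc4)cc(=O)c3c(O)c21` is built on a second core; the difference between the two cores is not broken down here. In this assay compound 3 reaches only a limit of the assay, > 50000 nM. Compound 4 `N#CC1=C(N)Oc2cc3oc(-c4ccccc4)cc(=O)c3c(O)c2C12C(=O)N(Cc1ccccc1)c1c(Cl)cccc12` has not yet been measured in this assay. It differs from compound 3 by chloro in place of methyl on an aromatic carbon. Among the measured compounds shown here, this is the same kind of change as the one from compound 1 to compound 2, but not the same: in compound 2 the chloro stands meta to a fused ring and para to a fused ring, whereas in compound 4 it stands ortho to a fused ring and meta to a fused ring.

Because the measured step of a 1.4-fold lower number from compound 1 to compound 2 (0.13 log units; within the scatter) lay within the scatter, the corresponding step is expected to be small as well, estimated as a number no higher from compound 3 to compound 4 (the limit leaves the size open). For compound 4 the expected value in this assay is 50000 nM, with an estimated range from 15000 nM to 100000 nM. Because compound 3 sits at the limit of > 50000 nM in this assay, at which 1 of the 3 values shown sits, compound 4 is expected most likely to be reported again only as a limit.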

Compound 4, half-maximal inhibitory concentration: 47800 nM
Compound 4: the middle estimate sits 1.0-fold (0.02 log units) above what was measured; the range from low to high includes it.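

In this assay, chloro in place of methyl on an aromatic carbon of the second core gave an at least 1.0-fold lower number from compound 3 to compound 4 (0.01 log units; that floor lies within the scatter). Compound 3 is recorded only as a limit of the assay, > 50000 nM, so this step is a floor and not a measured size. Set beside the step on the first core, it shows that neither printed figure lies beyond the scatter, but it does not show that the change carries over from one core to the other with the same size, and the chloro also occupies a different place on each core: the same change on two cores in this assay, a 1.4-fold lower number (0.13 log units; within the scatter) from compound 1 to compound 2 and an at least 1.0-fold lower number (0.01 log units; that floor lies within the scatter) from compound 3 to compound 4; the limit leaves it open whether they differ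

The compounds shown leave open how the chloro would behave if it stood on the core of compound 1 in the place it holds in compound 4, or on the core of compound 3 in the place it holds in compound 2, so core and place remain tied together here. They also leave open what other groups on this aromatic carbon, such as a methoxy group, an amine or a carboxylic acid, would do in this assay on either core.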